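A Rearranged Ring Group at the Assay Limit

The compounds below may be only part of what the source reports. "The series", "measured", "known", "first", "only" and "open" are said of these compounds alone.

Measured so far in an ADME assay on L1210 cells (Mus musculus) for cytotoxicity, with a stated time of 48 h; on this read-out lower numbers stand for stronger inhibition and higher numbers for weaker inhibition:
- Compound 1 `C=C1[C@H](C)CCC[C@]1(C)CC/C(C)=C/CC1=C(O)C(=O)C=C(N[C@@H](C(=O)O)C(C)C)C1=O`: 3.4 ug/mL
- Compound 2 `C=C1[C@H](C)CCC[C@]1(C)CC/C(C)=C/CC1=C(O)C(=O)C=C(N[C@H](C(=O)O)[C@@H](C)O)C1=O`: > 10 ug/mL
- Compound 3 `CC1=CCC[C@](C)(CC/C(C)=C/CC2=C(O)C(=O)C=C(N[C@@H](CO)C(=O)O)C2=O)[C@@H]1C`: > 10 ug/mL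

Compound 3 stands at > 10 ug/mL, which is a limit and not a number. It shares the limit of > 10 ug/mL in this assay, at which 2 of the 3 values shown sit, with compound 2, so only compound 1 has an exact place on the scale.

Compound 4 `C=C1[C@H](C)CCC[C@]1(C)CC/C(C)=C/CC1=C(O)C(=O)C=C(N[C@@H](CO)C(=O)O)C1=O` is reached from compound 3 by one exchange: a group of 9 heavy atoms (9 carbon; one six-membered non-aromatic ring of carbon only) in place of a group of 9 heavy atoms (9 carbon; one six-membered non-aromatic ring of carbon only), on a saturated chain carbon, two bonds along the chain from a double-bonded chain carbon. The two have the same atoms, joined differently, and the 1,2,3-trimethylcyclohex-3-en-1-yl group leaves.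

Among the compounds with values here, no measured step covers this exchange directly. The only one, an at least 2.9-fold higher number from compound 1 to compound 2 (0.46 log units; beyond the scatter), concerns a group on an amine nitrogen, and compound 3 and compound 4 do not differ there. It therefore gives no size for the present change. The entering group is already present in compound 2, which also sits at the limit of > 10 ug/mL. No step beyond the scatter is expected, and the expected result is a step that the limit leaves unreadable from compound 3 to compound 4. The estimate for compound 4 is 12 ug/mL, with an expected range from 5 ug/mL to 30 ug/mL.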

Compound 4, half-maximal inhibitory concentration: > 10 ug/mL
Compound 4: only a limit was reported; the forecaster's own chance of this, stated with the estimate: 65%; the middle value is on the limit's open side.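

In this assay, the group on the amine nitrogen now has a second readable step with the ring group held fixed: 1-carboxy-2-hydroxyethyl in place of 1-carboxy-2-methylpropyl gives an at least 2.9-fold higher number from compound 1 to compound 4 (0.46 log units; beyond the scatter), and this joins an at least 2.9-fold higher number from compound 1 to compound 2 (0.46 log units; beyond the scatter), where 1-carboxy-2-hydroxypropyl enters instead. The ring exchange itself remains unsized, as the steps from compound 3 to compound 4 and from compound 2 to compound 4 cannot be read, with a limit at both ends of each. Compound 4 also gives a limit and not a number, so most of the series now rests at one point on the scale: the limit of > 10 ug/mL in this assay, at which 3 of the 4 values shown sit.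

The compounds shown leave open whether the two ring groups differ at all, since a reading would need the 1,2,3-trimethylcyclohex-3-en-1-yl group paired with an amine substituent that gives an exact value, such as 1-carboxy-2-methylpropyl. They also leave open how far the exact value of compound 1 depends on the branched carbon chain of that substituent, which a 1-carboxy-3-methylbutyl group, with its longer chain, or a simple carboxymethyl group on the same nitrogen would test.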